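Compound 3 to compound 4: methyl replaces methoxy

This account rests on a few compounds, and the source may have more. Where it says the series, first, only, none or still open, it means among the compounds named here.

Measured in an ADME assay, at pH 3; a higher number here means that the compound lasts longer, a lower number that the compound disappears faster
Compound 1 `COc1cc2[nH]c([S+]([O-])Cc3nccc(OC)c3OC)nc2cc1OC(F)F` gives 0.25 h
Compound 2 `COc1cc2[nH]c([S+]([O-])Cc3nccc(OC)c3C)nc2cc1OC(F)F` gives 0.1 h
Compound 3 `COc1ccnc(C[S+]([O-])c2nc3cc(F)c(OC(F)F)cc3[nH]2)c1OC` gives 0.433 h

Compound 3 (0.433 h) lies within the scatter of compound 1 (0.25 h). Compound 2 (0.1 h) has a lower number than compound 3, and that gap lies beyond the scatter. Compound 4 `COc1ccnc(C[S+]([O-])c2nc3cc(F)c(OC(F)F)cc3[nH]2)c1C` carries methyl in place of methoxy on an aromatic carbon of compound 3. Among the compounds with values here, only one measured step shows this exchange (a 2.5-fold lower number from compound 1 to compound 2 (0.40 log units; beyond the scatter)), and it is modest but beyond the scatter. On that step a similar drop is expected in this assay, although that pair differs from compound 3 elsewhere on the core. The estimated change is a 2.5-fold lower number from compound 3 to compound 4 (0.41 log units; beyond the scatter) for this exchange. Compound 4 is expected at about 0.17 h, with an estimated range from 0.09 h to 0.32 h.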

Compound 4, half-life: 0.133 h
The estimate for compound 4 lay 1.3-fold (0.11 log units) above the measured number, and the stated range covers the measured number.
By their numbers in this assay, from the lowest: compounds 2, 4, 1 and 3 (each within the scatter of the next, the first and the last beyond it).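

In this assay, methyl in place of methoxy on an aromatic carbon gives a 3.3-fold lower number from compound 3 to compound 4 (0.51 log units; beyond the scatter), so the drop first seen on the core of compound 1 recurs on a second core. The two steps agree in direction and size: the same change on two cores in this assay, a 2.5-fold lower number (0.40 log units; beyond the scatter) from compound 1 to compound 2 and a 3.3-fold lower number (0.51 log units; beyond the scatter) from compound 3 to compound 4, 1.3-fold (0.11 log units) apart, within the scatter of two such steps. At this position, two atoms from the ring nitrogen, the exchange therefore reads alike on both cores.

Going by these compounds, only methoxy and methyl appear at this position, so the effect of an amine, a chlorine atom or a longer chain such as ethoxy remains open. These compounds also do not show why the number falls.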